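Swapping the aryl group for an arylamino group

The source may hold more compounds than are shown below. What is called first, only, known or untested is meant among the compounds shown, and "the series" means these compounds.

Measured in a functional assay on HL-60 cells (Homo sapiens) for antiproliferative activity, read by MTT assay, with a stated time of 72 h; a lower number here means a stronger inhibitor, a higher number a weaker inhibitor:
- compound 1 `COc1cc(C(=O)c2sc3ccccc3c2-c2ccc(F)cc2)cc(OC)c1OC`: 3200 nM
- compound 2 `COc1ccc(-c2c(C(=O)c3cc(OC)c(OC)c(OC)c3)sc3ccccc23)cc1C`: > 10000 nM

Compound 2 stands at > 10000 nM, which is a limit of the assay and not a number. Compound 3 `COc1cc(C(=O)c2sc3ccccc3c2Nc2ccc(C)cc2)cc(OC)c1OC` has not yet been measured. The change leading to it is (4-methylphenyl)amino in place of 4-methoxy-3-methylphenyl on an aromatic carbon of the five-membered aromatic ring with 1 sulfur. Within the data shown here, the one measured step at this carbon is an at least 3.1-fold higher number from compound 1 to compound 2 (0.49 log units; beyond the scatter), with 4-methoxy-3-methylphenyl in place of 4-fluorophenyl. Going by these compounds, that step lies beyond the scatter, so the group on this carbon can matter in this assay, but its full size is unknown. Among the measured compounds shown here, no measured compound carries the (4-methylphenyl)amino group, so the expectation rests on thin evidence. Compound 3 loses the 4-methoxy-3-methylphenyl group, and compound 1, which lacks that group too, gives 3200 nM. A move to a lower number is therefore expected, of modest size and uncertain, and a second limit reading remains possible. The expected step is an at least 3.3-fold lower number from compound 2 to compound 3 (0.52 log units; beyond the scatter). Compound 3 is estimated at 3000 nM, with an expected range from 600 nM to 10000 nM.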

Compound 3, half-maximal inhibitory concentration: 4600 nM
For compound 3 the middle estimate is 1.5-fold (0.19 log units) below the measured one; the range from low to high includes it.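

In this assay, the (4-methylphenyl)amino group on this aromatic carbon does about as well as the aryl group of the earlier active compound, with a 1.4-fold higher number from compound 1 to compound 3 (0.16 log units; within the scatter); a nitrogen-linked ring therefore reads the same here as a directly attached 4-fluorophenyl ring. Among these compounds, putting (4-methylphenyl)amino in place of 4-methoxy-3-methylphenyl gives an at least 2.1-fold lower number from compound 2 to compound 3 (0.33 log units; beyond the scatter), and among the three compounds only the one carrying 4-methoxy-3-methylphenyl stands apart from the others. Compound 2 gives a limit and not a number, and for this reason the true size of that step stays unknown: the limit of > 10000 nM in this assay, at which 1 of the 3 values shown sits.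

The compounds shown do not reveal whether the methoxy or the methyl of the 4-methoxy-3-methylphenyl group accounts for the weaker reading, and they offer no pair with the same ring attached with and without the amino nitrogen, leaving the link and the ring substituent entangled. Going by these compounds, it also stays open how a (4-fluorophenyl)amino group, an amino nitrogen bearing a methyl group, or a plain amine would read on this carbon.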